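The source may report more compounds than this note shows. Statements on the series, on what has been measured and on what is new or still open speak of the compounds shown alone.

Measured so far:
- compound 1 `Cn1c(-c2ccc(N)cc2Cl)nnc1C1(c2ccc(Cl)cc2)CCC1` gives 2300 nM in an assay on isolated protein for inhibition of 11-beta-hydroxysteroid dehydrogenase type 2 (Homo sapiens); a lower number here means a stronger inhibitor, a higher number a weaker inhibitor.
- compound 2 `Cn1c(-c2ccc(C(N)=O)cc2Cl)nnc1C1(c2ccc(Cl)cc2)CCC1` gives > 4000 nM in this assay, which is a limit of the assay and not a number.

Compound 2 therefore stands only at a limit in this assay, as the limit of > 4000 nM in this assay, at which 1 of the 2 values shown sits, records. Compound 3 `Cn1c(-c2ccc(-c3cccnc3)cc2Cl)nnc1C1(c2ccc(Cl)cc2)CCC1` differs from it by pyridin-3-yl in place of carbamoyl on an aromatic carbon. For the measured compounds named here, the single measured step, an at least 1.7-fold higher number from compound 1 to compound 2 (0.24 log units; that floor lies within the scatter), concerns amino against carbamoyl and does not bear on swapping carbamoyl for pyridin-3-yl, so no direction can be read from it. The expected step is a number no higher from compound 2 to compound 3 (the limit leaves the size open). Compound 3 is estimated at 4000 nM, within a range from 1000 nM to 15000 nM.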

Compound 3, half-maximal inhibitory concentration: > 4000 nM
Compound 3: only a limit was reported; the forecaster's own chance of this, stated with the estimate: 50%; the middle value lies on the limit itself.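

In this assay compound 3 gives > 4000 nM, which is a limit of the assay and not a number. Pyridin-3-yl in place of amino gives an at least 1.7-fold higher number from compound 1 to compound 3 (0.24 log units; that floor lies within the scatter), while the step between carbamoyl and pyridin-3-yl cannot be read, so a group with an aromatic ring has now reached the same limit as carbamoyl: the limit of > 4000 nM in this assay, at which 2 of the 3 values shown sit.

From the compounds shown here alone, how far compound 2 and compound 3 really lie from that limit stays open. So does whether a smaller group at this place, such as a hydroxyl or a methylamino group, would give a lower number than compound 1.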